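Removing One Methoxy Group on Two Related Cores

This account rests on a few compounds, and the source may have more. Where it says the series, first, only, none or still open, it means among the compounds named here.

Compound 1 `COc1ccc(C(=O)/C=C/c2cc(-c3cc(OC)c(OC)c(OC)c3)n[nH]2)cc1OC` and compound 2 `COc1ccc(C(=O)/C=C/c2cc(-c3cc(OC)c(OC)c(OC)c3)n[nH]2)cc1` share a core, and in a functional assay on MCF7 cells (Homo sapiens) for inhibition, read by MTT assay, with a stated time of 48 h (a lower number here means a stronger inhibitor, a higher number a weaker inhibitor), compound 1 gives 510 nM, while compound 2 gives 810 nM. The change between them is hydrogen in place of methoxy on an aromatic carbon, and it produced a 1.6-fold higher number from compound 1 to compound 2 (0.20 log units; within the scatter). Compound 3 `COc1ccc(-c2cc(/C=C/C(=O)c3cc(OC)c(OC)c(OC)c3)[nH]n2)cc1OC` has the same atoms as compound 1 joined differently; the difference between the two cores is not broken down here. In this assay compound 3 gives 1100 nM, which stands furthest from compound 1.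

Compound 4 `COc1ccc(-c2cc(/C=C/C(=O)c3cc(OC)c(OC)c(OC)c3)[nH]n2)cc1` is compound 3 after the same change, (hydrogen in place of methoxy on an aromatic carbon). The surroundings of the place are described in the same words for both pairs, so this is the same change carried onto a different core. Its measurement is still awaited. For compound 4 a step of similar size is expected, a 1.5-fold higher number from compound 3 to compound 4 (0.19 log units; within the scatter), because the earlier pair gave a 1.6-fold higher number from compound 1 to compound 2 (0.20 log units; within the scatter). Compound 4 is therefore estimated at 1700 nM, with a likely range from 900 nM to 3500 nM. This expectation rests on a single earlier pair and is held loosely.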

Compound 4, half-maximal inhibitory concentration: 2000 nM
Compound 4: middle estimate off by 1.2-fold (0.07 log units), on the low side; low and high end bracket the measured number.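

In this assay, replacing the methoxy group with hydrogen on the second core gives a 1.8-fold higher number from compound 3 to compound 4 (0.26 log units; within the scatter), and set beside the same change on the first core, the two steps agree: the same change on two cores in this assay, a 1.6-fold higher number (0.20 log units; within the scatter) from compound 1 to compound 2 and a 1.8-fold higher number (0.26 log units; within the scatter) from compound 3 to compound 4, 1.1-fold (0.06 log units) apart, within the scatter of two such steps. On these two cores, then, the step measured on one core was a fair guide to the step on the other, and the change from 3,4-dimethoxyphenyl to 4-methoxyphenyl carried across with much the same size. Each step alone still lies within the scatter, however, so the two pairs do not show that removing this methoxy group truly alters the number, and two cores are too few to speak for the whole series.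

The compounds shown carry only hydrogen in place of this methoxy group, which leaves open how a hydroxyl group, a fluorine atom or a longer chain such as ethoxy would read there. As far as these compounds go, whether steps of this size would recur in other cell lines also remains open.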